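A few compounds are considered here, and "the series" means these few. Any claim that something is new, unique, unknown or untested is made for them only; others in the source may bear on it.

Compound 1, `C=CC[N+](C)(C)c1ccc(OC)cc1`, in a functional assay with Cavia porcellus as the target (a lower number here means a stronger inhibitor, a higher number a weaker inhibitor), gives > 3000 nM, a limit of the assay.
Compound 2, `C=C(C)C[N+](C)(C)c1ccccc1O`, in this assay gives > 3000 nM, again only a limit.
Compound 3, `C=C(C)C[N+](C)(C)c1ccccc1OC`, in this assay gives > 3000 nM, again only a limit.

Compound 2 thus stands at no number but at the limit, where the other two values also sit (the limit of > 3000 nM in this assay, at which 3 of the 3 values shown sit). The one measured step among these compounds, a step that the two limits leave unreadable from compound 2 to compound 3, runs between two limits and its size cannot be read. The step to compound 4, `C=CCC[N+](C)(C)c1ccccc1O`, changes the group on the chain: allyl in place of 1-methylethenyl on a saturated chain carbon bound to a nitrogen on an aromatic ring. Going by the values given here, no measured step bears on this change with a readable size, and every value so far is a limit. Compound 4 is therefore expected to stay at or near the same limit, with an expected step that the limit leaves unreadable from compound 2 to compound 4 that is not beyond the scatter. Compound 4 is estimated at 6000 nM, with a range from 2000 nM to 30000 nM.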

Compound 4, half-maximal inhibitory concentration: > 10000 nM
Compound 4 gave a limit, no number; the forecaster's own chance of this, stated with the estimate: 80%; middle value at least 1.6-fold (0.22 log units) away from the limit.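

Compound 2 and compound 4 both give only limits, so no step can be read between them. The compounds shown leave open what number any of them would reach in this assay, and whether allyl in place of 1-methylethenyl changes it at all.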